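The compounds below may be only part of what the source reports. "The series", "measured", "known", "first", "only" and "open" are said of these compounds alone.

In a functional assay on 3T3-L1 cells (Mus musculus) for inhibition, with a stated time of 20 min, tested at 20 uM (on this read-out higher numbers stand for more inhibition at the one concentration tested (going by the name of the read-out) and lower numbers for less inhibition), compound 1 `Cc1ccc(S(=O)(=O)N(Cc2cccc(F)c2F)Cc2cn(S(=O)(=O)c3ccc(C)cc3)c3ccccc23)cc1` gives -13.9%, compound 2 `Cc1ccc(S(=O)(=O)N(Cc2cccc(F)c2F)Cc2cn(S(=O)(=O)c3ccc(F)cc3)c3ccccc23)cc1` gives -35%, and compound 3 `Cc1ccc(S(=O)(=O)N(Cc2cn(Cc3cc(F)ccc3F)nn2)Cc2cn(S(=O)(=O)c3ccccc3)c3ccccc23)cc1` gives -6.5%. All three numbers lie below zero, so none of them shows inhibition at the concentration tested. Compound 1 stands second highest of the three; its nearest neighbour is compound 3, whose number is within the scatter of it, and its furthest is compound 2, reached by a number 21.1 percentage points lower from compound 1 to compound 2 (beyond the scatter), a change of fluoro in place of methyl on an aromatic carbon.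

Compound 4 `Cc1ccc(S(=O)(=O)n2cc(CN(Cc3cccc(F)c3F)S(C)(=O)=O)c3ccccc32)cc1` differs from compound 1 by methyl in place of 4-methylphenyl on a sulfonyl sulfur. For the measured compounds named here, no measured step touches that sulfonyl sulfur: the only step known changes a group on a different part of the molecule, and its size, measured by a number 21.1 percentage points lower from compound 1 to compound 2 (beyond the scatter), says little about swapping the whole 4-methylphenyl for a methyl. With no guide from a comparable change, and with every measured number sitting close to zero or below it, the expectation is a step of no clear size: a number 1.9 percentage points higher from compound 1 to compound 4 (within the scatter) is estimated to stay within the scatter. Compound 4 is therefore expected to give about -12%, with a likely range from -38% to 12%.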

Compound 4, a percentage reported as inhibition, at one concentration (the size of the read-out at that concentration, not a potency): -3.3%
Beside the measured number, compound 4's estimate is 8.7 percentage points below it; the measured number falls inside the stated range.
By their numbers in this assay, from the lowest: compound 2; then compounds 1, 3 and 4 (each within the scatter of the next, the first and the last beyond it).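

For the compounds shown here, the first measured change at this sulfonyl sulfur, a swap of the 4-methylphenyl for a methyl next to the sulfonamide nitrogen's sulfur bond, is a step of a number 10.6 percentage points higher from compound 1 to compound 4 (beyond the scatter). So this position does respond in this assay: the number moves beyond the scatter when the six-membered aromatic ring leaves and a single carbon takes its place. Even so, compound 4 gives -3.3%, which is still under zero, so this change moves the read-out without producing any inhibition at the concentration tested, and nothing available explains why the number shifts.

The compounds shown leave open whether a different group on this sulfonyl sulfur, such as a longer chain like butyl, an amine or a carboxylic acid, would lift the number above zero. Going by these compounds, it also remains open whether the same swap to methyl would give a step of similar size in compound 2, where a fluoro stands in place of the methyl on the other aromatic ring.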